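The compounds below may be only part of what the source reports. "The series", "measured", "known", "first", "only" and "open" are said of these compounds alone.

Measured so far in a functional assay on HepG2 cells (Homo sapiens) for inhibition, read by MTT assay, with a stated time of 48 h; a higher number here means a weaker inhibitor, a lower number a stronger inhibitor:
- Compound 1 `C[Se]c1ccc(N(C)c2nc(C3CC3)nc3ccccc23)cc1`: 32 nM
- Compound 2 `COc1ccc(N(C)c2nc(C)nc3ccccc23)cc1C(=O)OCCC[Se]C#N`: 340 nM
- Compound 3 `Cc1nc(N(C)c2ccc(OCC[Se]C#N)cc2)c2ccccc2n1`: 1680 nM

Compound 2, at 340 nM, holds the middle place among these three numbers. Compound 3 reads higher at 1680 nM, so it is the weaker inhibitor, and compound 1 reads lower at 32 nM, so it is the stronger one. Both gaps from compound 2 lie beyond the usual scatter.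

Compound 4 `COc1ccc(N(C)c2nc(C)nc3ccccc23)cc1C[Se]C#N` has not yet been measured. It differs from compound 2 in one place: a group of 4 heavy atoms (2 carbon, 1 nitrogen, 1 selenium; no ring) in place of a group of 9 heavy atoms (5 carbon, 1 nitrogen, 2 oxygen, 1 selenium; no ring), on an aromatic carbon. Going by the values given here, no pair of measured compounds differs in just one place, so the data do not show directly what a change like this does. The three measured compounds differ in more than one place, which makes any comparison among them loose. Compound 3 also carries selenium and a nitrile and gives 1680 nM, so a number in that upper region cannot be ruled out for compound 4. Even so, the expectation in this assay is a small move toward a lower number, one that stays within the scatter. The estimated change is a 1.5-fold lower number from compound 2 to compound 4 (0.19 log units; within the scatter). The expected value for compound 4 is 220 nM, with an estimated range from 60 nM to 800 nM.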

Compound 4, half-maximal inhibitory concentration: 1110 nM
Compound 4: the middle estimate sits 5.0-fold (0.70 log units) below what was measured, and the stated range ends below it.
By their numbers in this assay, from the lowest: compound 1; then compound 2; then compounds 4 and 3 (each within the scatter of the next).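

In this assay, going by these compounds alone, this is the first pair of measured compounds that differ in one place only, so the effect of a change on this aromatic carbon, ortho to a methoxy group, can now be read directly: a 3.3-fold higher number from compound 2 to compound 4 (0.51 log units; beyond the scatter). The step is modest but beyond the scatter, which shows that the number responds to what is attached here, even though the entering and the leaving group both hold selenium and a nitrile; the group of 9 heavy atoms, with its carbonyl, gives the stronger inhibitor of the two. No measurement at hand explains this step.

The compounds shown leave open which part of the larger group matters, whether its carbonyl and ester oxygen or simply its length, and an all-carbon chain ending in the same selenium and nitrile would help separate the two. They also leave open how a carboxylic acid or an amine would read on this carbon, and whether the same change would give a similar step on the core of compound 1.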